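Dichlorophenyl isomers in the series: compound 3 to compound 4

A few compounds are considered here, and "the series" means these few. Any claim that something is new, unique, unknown or untested is made for them only; others in the source may bear on it.

- compound 1 `COc1ccc(/C=C2\CCC/C(=C\c3cccc(O)c3)C2=O)cc1OC` gives 1900 nM 
- compound 2 `COc1ccc(/C=C2\CCC/C(=C\c3ccc(Cl)cc3Cl)C2=O)cc1OC` gives 10300 nM 
- compound 3 `COc1ccc(/C=C2\CCC/C(=C\c3ccc(Cl)c(Cl)c3)C2=O)cc1OC` gives 4000 nM 

In a functional assay on SW-620 cells (Homo sapiens) for cytotoxicity, read by MTT assay, with a stated time of 72 h (a lower number here means a stronger inhibitor, a higher number a weaker inhibitor), compound 3 (4000 nM) holds the middle place of the three numbers. Compound 4 `COc1ccc(/C=C2\CCC/C(=C\c3cc(Cl)cc(Cl)c3)C2=O)cc1OC` carries one change: 3,5-dichlorophenyl in place of 3,4-dichlorophenyl on a double-bonded chain carbon bound to a double-bonded ring carbon on a double-bonded chain carbon bound to a double-bonded ring carbon. Among the compounds with values here, the closest precedent, the only step between dichlorophenyl groups, is a 2.6-fold lower number from compound 2 to compound 3 (0.41 log units; beyond the scatter) and counts as modest. The steps of a 5.4-fold higher number from compound 1 to compound 2 (0.73 log units; beyond the scatter) and a 2.1-fold higher number from compound 1 to compound 3 (0.32 log units; beyond the scatter) replace the 3-hydroxyphenyl group and bear less directly. With a single precedent the direction remains uncertain, though a slightly higher number is expected. The expected change is a 1.3-fold higher number from compound 3 to compound 4 (0.10 log units; within the scatter) and no more than modest. For compound 4 the estimate is 5000 nM with an expected range of 2200 nM to 11000 nM in this assay here.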

Compound 4, half-maximal inhibitory concentration: 2500 nM
Beside the measured number, compound 4's estimate is 2.0-fold (0.30 log units) above it; the range from low to high includes it.
By their numbers in this assay, from the lowest: compounds 1, 4 and 3 (each within the scatter of the next, the first and the last beyond it); then compound 2.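

In this assay, the 3,5-dichlorophenyl group does not separate from the 3,4-dichlorophenyl group, with a 1.6-fold lower number from compound 3 to compound 4 (0.20 log units; within the scatter), so of the dichlorophenyl isomers shown only the 2,4-dichlorophenyl compound stands apart, as a 4.1-fold lower number from compound 2 to compound 4 (0.61 log units; beyond the scatter) confirms. Nor does the 3,5-dichlorophenyl group separate from the 3-hydroxyphenyl group, with a 1.3-fold higher number from compound 1 to compound 4 (0.12 log units; within the scatter), although the 3,4-dichlorophenyl group does. No evidence bears on the reason for these results. Open, on these data alone, is how a phenyl group carrying an amine or a carboxylic acid would read at this place.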